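The compounds below may be only part of what the source reports. "The series", "measured", "known", "first", "only" and "open" are said of these compounds alone.

In a functional assay on HT-29 cells (Homo sapiens) for antiproliferative activity, read by sulforhodamine B assay, with a stated time of 48 h (on this read-out lower numbers stand for stronger inhibition and higher numbers for weaker inhibition), compound 1 (`O=C1NCCN1c1ccc(S(=O)(=O)Nc2ccc(I)cc2)cc1`) gives 650 nM and compound 2 (`Cc1cccc(NS(=O)(=O)c2ccc(N3CCNC3=O)cc2)c1C`) gives 190 nM as the lower of the two numbers, so compound 2 stands lowest so far. Compound 3 (`COc1ccc(NS(=O)(=O)c2ccc(N3CCNC3=O)cc2)cc1`) is still unmeasured and carries 4-methoxyphenyl in place of 2,3-dimethylphenyl on a sulfonamide nitrogen. Among the compounds with values here, one measured step bears on this change (a 3.4-fold lower number from compound 1 to compound 2 (0.53 log units; beyond the scatter)), a modest step in which 2,3-dimethylphenyl replaced 4-iodophenyl at that same place. Within the data shown here, no measured compound carries 4-methoxyphenyl, so this single step is only a loose guide. Compound 3 gives up the group that compound 2 carries at 190 nM as the lower number, and a change of similar modest size toward a higher number is therefore expected. The step estimated in this assay is a 2.6-fold higher number from compound 2 to compound 3 (0.42 log units; beyond the scatter) and carries wide uncertainty. The value expected for compound 3 is 500 nM within an estimated range of 130 nM to 1800 nM (an expectation that awaits measurement).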

Compound 3, half-maximal inhibitory concentration: 800 nM
The estimate for compound 3 lay 1.6-fold (0.20 log units) below the measured number; low and high end bracket the measured number.
By their numbers in this assay, from the lowest: compound 2; then compounds 1 and 3 (each within the scatter of the next).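

In this assay the sulfonamide nitrogen now carries a third group, and 4-methoxyphenyl in place of 2,3-dimethylphenyl brings a 4.2-fold higher number from compound 2 to compound 3 (0.62 log units; beyond the scatter) in a step of the same modest class as the earlier change from 4-iodophenyl. Methoxy in place of iodo on an aromatic carbon gives a 1.2-fold higher number from compound 1 to compound 3 (0.09 log units; within the scatter) and so leaves 4-methoxyphenyl and 4-iodophenyl indistinguishable at this place, which makes 2,3-dimethylphenyl the only one of the three groups whose number stands apart from the other two. No measurement offered alongside these numbers accounts for that separation.

The compounds shown leave open whether the lower number of compound 2 depends on both methyl groups of 2,3-dimethylphenyl or would survive with a single methyl group on the phenyl ring. They also leave open how this assay would respond at the sulfonamide nitrogen to a group of another kind, such as an amine, a carboxylic acid or a benzyl group, since all three compounds carry a substituted phenyl ring there.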